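The source may report more compounds than this note shows. Statements on the series, on what has been measured and on what is new or still open speak of the compounds shown alone.

Compound 1 `NC(=O)CC[C@H](NC(=O)CN(c1ncnc2c1ncn2C1CCCCO1)C1CC1)C(=O)OCc1ccccc1` gives 39.4% in a functional assay on the whole organism (Tail, strain ICR) with Mus musculus as the target, in the tail flick test, with a stated time of 60 min, at a dose of 25 umol/kg by the oral route; on this read-out lower numbers stand for a weaker effect and higher numbers for a stronger effect at the one dose given. Compound 2 `C[C@@H](O)[C@H](NC(=O)CN(c1nc(Cl)nc2[nH]cnc12)C1CC1)C(=O)OCc1ccccc1` gives 29.7% in this assay, a number that lies within the usual scatter of compound 1, so the two cannot be told apart on the numbers shown. Compound 3 `CC[C@H](C)[C@H](NC(=O)CN(c1ncnc2c1ncn2C1CCCCO1)C1CC1)C(=O)OCc1ccccc1` has not been tested in this assay. It differs from compound 1 in one place: sec-butyl in place of 2-carbamoylethyl on a saturated chain carbon bound to an amide-type nitrogen and a carbonyl carbon. Going by the values given here, no measured pair shows a change of this kind, so the expected step is only a number 4.4 percentage points lower from compound 1 to compound 3 (within the scatter), not clearly beyond the scatter. Compound 3 is therefore expected to give 35% in this assay, with a range from 15% to 55%.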

Compound 3, a percentage reported as activity, at one dose (the size of the read-out at that dose, not a potency): 27.4%
Compound 3: middle estimate off by 7.6 percentage points, on the high side; measured number inside the range.
By their numbers in this assay, from the lowest: compounds 3, 2 and 1 (each within the scatter of the next, the first and the last beyond it).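

In this assay, going by these compounds alone, this is the first single change whose size can be read: at the saturated chain carbon bound to an amide-type nitrogen and a carbonyl carbon, sec-butyl in place of 2-carbamoylethyl gives a number 12 percentage points lower from compound 1 to compound 3 (beyond the scatter). The effect does not disappear without the hydrogen-bond donor and acceptor counted on 2-carbamoylethyl, as compound 3 still gives 27.4%. No measurement shown accounts for this step. As far as these compounds go, whether an amine, a carboxylic acid or a longer chain at this place would match compound 1 or compound 3 remains open.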